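The source may hold more compounds than are shown below. What is called first, only, known or untested is meant among the compounds shown, and "the series" means these compounds.

Measured so far:
compound 1 `Cc1ccccc1C(=O)N(NC(=O)c1ccccc1)C(C)(C)C` – 224 nM
compound 2 `CC(C)(C)N(NC(=O)c1ccccc1I)C(=O)c1ccccc1Cl` – 1290 nM

In an assay on cells for agonist activity at ecdysone receptor (Bombyx mori), read by a luciferase reporter, with a stated time of 24 h (a higher number here means that more compound is needed for the effect, a lower number that less compound is needed), compound 1 gives 224 nM and compound 2 gives 1290 nM. Compound 2 thus carries the higher of the two numbers, and its gap to compound 1 lies beyond the scatter. Among the compounds with values here, no step between compounds differing in a single place is available; compound 1 and compound 2 differ in more than one place, so only their two values can be compared.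

Compound 3 `COc1cccc(C(=O)NN(C(=O)c2ccccc2Cl)C(C)(C)C)c1` is not yet measured. It differs from compound 2 by 3-methoxyphenyl in place of 2-iodophenyl on a carbonyl carbon. Within the data shown here, with no matched step to lean on, a moderate move downward in this assay is expected for compound 3, since compound 1 gives 224 nM while compound 2 gives 1290 nM. The expected step from compound 2 to compound 3 is a 2.9-fold lower number from compound 2 to compound 3 (0.46 log units; beyond the scatter). For compound 3 the estimate is 450 nM, with a range from 120 nM to 1800 nM.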

Compound 3, half-maximal effective concentration: 52.5 nM
Compound 3: the middle estimate sits 8.6-fold (0.93 log units) above what was measured, outside the stated range (below it).
By their numbers in this assay, from the lowest: compound 3; then compound 1; then compound 2.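

Within the data shown here, at the carbonyl carbon whose other neighbour is the amide-type nitrogen, the aryl group turns out to be a strong lever in this assay: 3-methoxyphenyl in place of 2-iodophenyl gives a 25-fold lower number from compound 2 to compound 3 (1.39 log units; beyond the scatter) and so provides the first single-place reading. The swap exchanges iodine for oxygen, adds a hydrogen-bond acceptor and alters the ring numbering of the substituent all at once, so the size of the step cannot be divided among these differences. Nothing at hand accounts for the step.

Still open, as far as these compounds go, is whether the methoxy group itself or its place on the ring carries this step. From the compounds shown here alone, it is also open how a hydroxyl group or an amine at the same ring place would read in this assay and whether the step would persist with another group at the second carbonyl.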